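Taking the 4-methylpiperazin-1-yl group off compound 1

The source may report more compounds than this note shows. Statements on the series, on what has been measured and on what is new or still open speak of the compounds shown alone.

In a functional assay on K562 cells (Homo sapiens) for antiproliferative activity, read by MTT assay, with a stated time of 72 h (on this read-out lower numbers stand for stronger inhibition and higher numbers for weaker inhibition), compound 1 (`CN1CCN(c2cccc(C(=O)/C=C/c3ccc(/C=C/C(=O)NO)cc3)c2)CC1`) gives 850 nM and sits level with its nearest neighbour in the set. That neighbour, compound 3 (`CN1CCN(c2cccc(C(=O)/C=C/c3cccc(/C=C/C(=O)NO)c3)c2)CC1`), gives 990 nM and the two numbers lie within the scatter of each other. Compound 2 (`CN1CCN(c2cccc(C(=O)/C=C/c3cccc(/C=C/C(=O)NO)n3)c2)CC1`) gives 110 nM as a lower number, and its distance from compound 1 lies beyond the scatter.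

Compound 4 (`O=C(/C=C/c1ccc(/C=C/C(=O)c2ccccc2)cc1)NO`) has hydrogen in place of 4-methylpiperazin-1-yl on an aromatic carbon. All three measured compounds carry that group, so nothing measured here shows directly what its removal does. The expectation in this assay is therefore a moderate step toward a higher number, meaning weaker inhibition, although this rests on little evidence. The estimated change is a 2.1-fold higher number from compound 1 to compound 4 (0.33 log units; beyond the scatter) on this reasoning. Compound 4 is expected to read about 1800 nM with an estimated range from 600 nM to 5500 nM in this test.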

Compound 4, half-maximal inhibitory concentration in the K562 assay: 2280 nM
Estimate against measurement, compound 4: 1.3-fold (0.10 log units) below, within the range that was stated.
By their numbers in the K562 assay, from the lowest: compound 2; then compounds 1 and 3 (each within the scatter of the next); then compound 4.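

For the compounds shown here, in the K562 assay, replacing 4-methylpiperazin-1-yl with hydrogen gives a 2.7-fold higher number from compound 1 to compound 4 (0.43 log units; beyond the scatter), the first direct reading of this change, since the earlier compounds all carry the group at this position. The group is therefore not essential for activity in the K562 assay, where compound 4 still gives 2280 nM, although the step is beyond the scatter. The same change also comes with a clear drop in a physicochemical assay for solubility, at pH 7.4 (a higher number here means a more soluble compound, a lower number a less soluble compound), where compound 1 gives 16000 nM and compound 4 gives 3000 nM: the measured solubility of compound 1, 16000 nM, and of compound 4, 3000 nM, a 5.3-fold lower number (0.73 log units; beyond the scatter)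

The compounds shown cannot separate the step in the K562 assay from the drop in solubility, nor say whether the same removal would cost as much on the core of compound 2. They also leave open whether a different amine at this place, such as morpholin-4-yl or dimethylamino, or a carboxylic acid, would read like 4-methylpiperazin-1-yl or like hydrogen.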